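The source may hold more compounds than are shown below. What is called first, only, known or untested is meant among the compounds shown, and "the series" means these compounds.

Compound 1 `CN1CCN(CCCn2c3c(c4ccccc42)C(=O)c2c[n+]([O-])c4ccccc4c2C3=O)CC1`: 220 nM
Compound 2 `CN1CCN(CCCCCCn2c3c(c4ccccc42)C(=O)c2c[n+]([O-])c4ccccc4c2C3=O)CC1`: 400 nM
Compound 3 `CN(C)CCCCn1c2c(c3ccccc31)C(=O)c1c[n+]([O-])c3ccccc3c1C2=O`: not yet measured

In a functional assay on MCF7 cells (Homo sapiens) for cytotoxicity, read by MTT assay, with a stated time of 72 h (a lower number here means a stronger inhibitor, a higher number a weaker inhibitor), compound 2, at 400 nM, stands within the scatter of compound 1. The move to compound 3 is dimethylamino in place of 2-(4-methylpiperazin-1-yl)ethyl on a saturated chain carbon, four bonds along the chain from an aromatic nitrogen. Among the compounds with values here, only one measured step bears on this, a 1.8-fold higher number from compound 1 to compound 2 (0.26 log units; within the scatter), and it changes the chain while keeping the 4-methylpiperazin-1-yl end. Within the data shown here, no measured step exchanges that end group, so the evidence is indirect, and no change beyond the scatter is expected in this assay. The expected step is a 1.3-fold lower number from compound 2 to compound 3 (0.12 log units; within the scatter). For compound 3 the estimate is 300 nM, with an expected range of 100 nM to 900 nM.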

Compound 3, half-maximal inhibitory concentration: 220 nM
Compound 3: the middle estimate sits 1.4-fold (0.13 log units) above what was measured; the range from low to high includes it.
By their numbers in this assay, from the lowest: compounds 1, 3 and 2 (each within the scatter of the next).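

In this assay, within the data shown here, the end group itself changes for the first time, and dimethylamino in place of 2-(4-methylpiperazin-1-yl)ethyl gives a 1.8-fold lower number from compound 2 to compound 3 (0.26 log units; within the scatter) and the comparison with the other piperazine compound gives no change at the digits printed from compound 1 to compound 3 (within the scatter). Both steps lie within the scatter, so among these compounds the piperazine ring is not required to keep the number in this range. Nothing measured here offers an explanation for this.

The compounds shown leave open how a morpholine, a primary amine or a carboxylic acid would read at the chain end. They also leave open how dimethylamino would read on a longer chain.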